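A few compounds are considered here, and "the series" means these few. Any claim that something is new, unique, unknown or untested is made for them only; others in the source may bear on it.

In a functional assay, with a stated time of 6 min (on this read-out higher numbers stand for weaker inhibition and lower numbers for stronger inhibition), compound 1 `Fc1cccc(NCn2nc(-c3ccc4c(c3)OCCO4)oc2=S)c1` gives 6620 nM and compound 2 `S=c1oc(-c2ccc3c(c2)OCCO3)nn1CNc1ccc(Cl)cc1` gives 7270 nM. With only these two numbers available, compound 2 stands level with compound 1, and the two cannot be ranked. Compound 3 `S=c1oc(-c2ccc3c(c2)OCCO3)nn1CNc1ccc(Br)cc1` differs from compound 2 by one small edit: bromo in place of chloro on an aromatic carbon. This is bromo in place of chloro on an aromatic carbon, para to a large group. Within the data shown here, the one measured step that bears on this edit is a 1.1-fold higher number from compound 1 to compound 2 (0.04 log units; within the scatter), which replaced 3-fluorophenyl with 4-chlorophenyl on an amine nitrogen. Among the measured compounds shown here, no measured pair shows chloro exchanged for bromo directly, so this evidence is indirect and thin. Resting on that small step, no shift beyond the scatter is expected in this assay. The expected step is a 1.0-fold lower number from compound 2 to compound 3 (0.02 log units; within the scatter). For compound 3 the estimated value is 7000 nM, with an expected range from 3500 nM to 14000 nM.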

Compound 3, half-maximal inhibitory concentration: 14700 nM
Compound 3: middle estimate off by 2.1-fold (0.32 log units), on the low side; the whole stated range lies below it.
By their numbers in this assay, from the lowest: compounds 1 and 2 (each within the scatter of the next); then compound 3.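

In this assay this place on the ring turns out not to be indifferent to the halogen: bromo in place of chloro gives a 2.0-fold higher number from compound 2 to compound 3 (0.31 log units; beyond the scatter) and so weaker inhibition, although the change is only modest. The 4-bromophenyl group also separates from the 3-fluorophenyl group, with a 2.2-fold higher number from compound 1 to compound 3 (0.35 log units; beyond the scatter) showing weaker inhibition, whereas the 4-chlorophenyl group stood level with the 3-fluorophenyl group. No measurement shown here accounts for why this single exchange of one halogen atom for another shifts the number.

Still open, as far as these compounds go, is whether a methoxy group, a nitrile or a plain hydrogen on this same aromatic carbon would give stronger or weaker inhibition than chloro or bromo. From the compounds shown here alone, it is also open whether the step from chloro to bromo would appear again on a different core.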